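Paw edema series: step from compound 3 to compound 4

The source may report more compounds than this note shows. Statements on the series, on what has been measured and on what is new or still open speak of the compounds shown alone.

Measured compounds and values:
compound 1 `CC/N=c1/c(C#N)c2n(c(=O)n1-c1ccccc1)CCC2` — 30.4%
compound 2 `N#Cc1ccc(/N=c2\c(C#N)c3n(c(=O)n2-c2ccccc2)CCC3)cc1` — 23.6%
compound 3 `N#CC1=C(NCCN)N(c2ccccc2)C(=O)N2CCCC12` — 16.9%

In a functional assay on the whole organism (strain albino) for inhibition, with Rattus norvegicus as the target, read by paw edema, with a stated time of 4 h, at a dose of 0.029 mmol/kg by the oral route (a lower number here means less inhibition, a higher number more inhibition at the dose given (going by the name of the read-out)), compound 3 gives 16.9%, the lowest of the three numbers. Compound 2 sits above it by a gap within the usual scatter, so no order between compound 3 and compound 2 is claimed; compound 1 stands higher by a gap beyond the scatter.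

Compound 4 `CCO/C=N/C1=C(C#N)C2CCCN2C(=O)N1c1ccccc1` has not been measured. It differs from compound 3 at one place: a group of 5 heavy atoms (3 carbon, 1 nitrogen, 1 oxygen; no ring) in place of a group of 4 heavy atoms (2 carbon, 2 nitrogen; no ring), on a double-bonded ring carbon. Within the data shown here, no step between measured compounds matches this change, so no measured guide exists. The new group carries a double bond outside aromatic rings, as do the groups in compound 1 and compound 2, which gave the higher numbers; a modest rise is therefore expected, of a size around the scatter, with a number 7.1 percentage points higher from compound 3 to compound 4 (within the scatter) as the expected step. For compound 4 a value of 24% is estimated, with a range from 12% to 36%.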

Compound 4, a percentage reported as inhibition, in the whole organism at one dose (the size of the read-out at that dose, not a potency): 4.96%
Compound 4: the middle estimate sits 19 percentage points above what was measured, outside the stated range (below it).
By their numbers in this assay, from the lowest: compound 4; then compounds 3, 2 and 1 (each within the scatter of the next, the first and the last beyond it).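

In this assay, replacing (2-aminoethyl)amino on the double-bonded ring carbon gives a number 11.9 percentage points lower from compound 3 to compound 4 (beyond the scatter), so the number at this position changes with the group it carries. The entering group has a double bond outside aromatic rings and 0 hydrogen-bond donors, and in this single step the double bond brings no rise. Nothing measured here explains the fall. The compounds shown leave open how a plain amino group or the longer (3-aminopropyl)amino chain would stand at this carbon. The hydrogen-bond donors and the rest of the group therefore remain unseparated.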